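Trifluoromethoxy Added to Compound 2: An Expected Step

This account rests on a few compounds, and the source may have more. Where it says the series, first, only, none or still open, it means among the compounds named here.

Measured so far:
compound 1 `CCCCOc1ccc(Nc2nc3nonc3nc2O)cc1` 3700 nM
compound 2 `Oc1nc2nonc2nc1Nc1ccccc1` 66700 nM
compound 3 `CCc1ccc(Nc2nc3nonc3nc2O)cc1` 10700 nM

In an assay on mitochondria from L6 cells (Rattus norvegicus) for activation, with a stated time of 90 min (a higher number here means that more compound is needed for the effect, a lower number that less compound is needed), compound 2 gives 66700 nM, the highest of the three numbers. Its nearest neighbour is compound 3 at 10700 nM, and compound 1 lies furthest at 3700 nM. Compound 4 `Oc1nc2nonc2nc1Nc1cccc(OC(F)(F)F)c1` has not yet been measured. It differs from compound 2 in one place: trifluoromethoxy in place of hydrogen on an aromatic carbon.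

Within the data shown here, two measured steps bear on this change, since both put a group onto the otherwise bare aromatic ring of compound 2. Going a 6.2-fold lower number from compound 2 to compound 3 (0.79 log units; beyond the scatter) gives a modest lowering of the number in this assay; read backwards, an 18-fold higher number from compound 1 to compound 2 (1.26 log units; beyond the scatter) shows the removal of butoxy raising the number by a large amount. Both groups that enter differ from trifluoromethoxy, and the place in compound 4 is described as meta to a large group, which neither step tests directly. A lowering beyond the scatter is therefore expected, but one kept to a modest size. Compound 4 is estimated at 12000 nM, within 4000 nM to 40000 nM, which means an expected step of a 5.6-fold lower number from compound 2 to compound 4 (0.74 log units; beyond the scatter).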

Compound 4, half-maximal effective concentration: 5100 nM
Estimate against measurement, compound 4: 2.4-fold (0.37 log units) above; measured number inside the range.
By their numbers in this assay, from the lowest: compounds 1 and 4 (each within the scatter of the next); then compound 3; then compound 2.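

The result shows that this place, meta to a large group, responds strongly in this assay: trifluoromethoxy in place of hydrogen gives a 13-fold lower number from compound 2 to compound 4 (1.12 log units; beyond the scatter), a step classed as large. The earlier compounds shown here showed only ethyl and butoxy entering the bare ring, and the step with ethyl, a 6.2-fold lower number from compound 2 to compound 3 (0.79 log units; beyond the scatter), was classed as modest, so compound 4 adds a large step from a different group at a place neither of those steps tested.

The compounds shown leave open whether the size of this step belongs to trifluoromethoxy or to its place, as no compound here carries the same group on the ring carbon that holds ethyl in compound 3, or a different group at the place it holds in compound 4. Whether a methoxy group, a chlorine atom, an amine or a carboxylic acid at this place would lower the number as well also stays unanswered, and nothing measured here gives an explanation for the size of the step.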